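The compounds below may be only part of what the source reports. "The series", "measured", "known", "first", "only" and "open" are said of these compounds alone.

Compound 2 `O=[N+]([O-])c1cn2c(n1)OC[C@@H](NCc1ccc(OC(F)(F)F)cc1F)C2` and compound 1 `CN(Cc1ccc(OC(F)(F)F)cc1)[C@@H]1COc2nc([N+](=O)[O-])cn2C1` share a core that carries a nitroimidazole-derived bicyclic system and a trifluoromethoxy-substituted benzyl amine. In an in vitro ADME assay on the whole organism (microsomes, liver, Mus musculus) for metabolic stability, read by LC-MS, with a stated time of 24 h, at a dose of 5 mg/kg by the intravenous route (on this read-out lower numbers stand for a shorter-lived compound and higher numbers for a longer-lived compound), compound 2 gives 0.242 h, and compound 1 gives 0.183 h; the two numbers lie within the scatter of each other, so neither can be called longer-lived. Compound 3 `O=[N+]([O-])c1cn2c(n1)OC[C@@H](NCc1ccc(OC(F)(F)F)cc1Cl)C2` differs from compound 2 by chloro in place of fluoro on an aromatic carbon. Going by the values given here, no step between measured compounds bears on this change, so no shift beyond the scatter is expected for a 1.1-fold higher number from compound 2 to compound 3 (0.05 log units; within the scatter). Compound 3 is estimated at 0.27 h in this assay, with a range from 0.15 h to 0.5 h.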

Compound 3, half-life: 0.332 h
Estimate against measurement, compound 3: 1.2-fold (0.09 log units) below, and the stated range covers the measured number.
By their numbers in this assay, from the lowest: compounds 1, 2 and 3 (each within the scatter of the next).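

In this assay, chloro in place of fluoro on this aromatic carbon, ortho to a large group and meta to a trifluoromethoxy group, gives a 1.4-fold higher number from compound 2 to compound 3 (0.14 log units; within the scatter), a step within the scatter. At this position the two halogens therefore cannot be told apart on this read-out. No measurement at hand offers an explanation for this result. On these data alone, it remains open whether a methoxy group, a nitrile or an amine on this carbon would move the half-life beyond the scatter. Also open, as far as these compounds go, is whether chloro here gives the same result alongside the methyl group on the amine of compound 1.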